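This account rests on a few compounds, and the source may have more. Where it says the series, first, only, none or still open, it means among the compounds named here.

Measured so far:
compound 1 `C#CCN(CCCCOc1ccc2ccc(=O)oc2c1)Cc1ccc(OC)cc1` — in an assay on isolated protein for inhibition of Amine oxidase [flavin-containing] B (Homo sapiens), read by fluorescence and Amplex Red, with stated times of 15 min and 20 min (a lower number here means a stronger inhibitor, a higher number a weaker inhibitor), compound 1 gives 1130 nM
compound 2 `C#CCN(CCCCOc1ccc2ccc(=O)oc2c1)Cc1cccc(OC)c1` — in this assay compound 2 gives 2340 nM

For the measured compounds named here, compound 2 stands highest of the two numbers, with compound 1 the nearest; the one measured step, a 2.1-fold higher number from compound 1 to compound 2 (0.32 log units; beyond the scatter), separates them. Compound 3 `C#CCN(CCCCOc1ccc2ccc(=O)oc2c1)Cc1ccc(C(C)C)cc1` arises from compound 2 through (4-isopropylphenyl in place of 3-methoxyphenyl on a saturated chain carbon bound to an amine nitrogen). Going by the values given here, only that step bears on this change, and only in part: it covers moving the methoxy group, while no measured step covers the isopropyl group. A modest lowering of the number is therefore expected, a 1.7-fold lower number from compound 2 to compound 3 (0.22 log units; within the scatter), with wide uncertainty. For compound 3 the expected value in this assay is 1400 nM, in the range 450 nM to 4500 nM.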

Compound 3, half-maximal inhibitory concentration: 3500 nM
The estimate for compound 3 lay 2.5-fold (0.40 log units) below the measured number; the range from low to high includes it.
By their numbers in this assay, from the lowest: compound 1; then compounds 2 and 3 (each within the scatter of the next).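

In this assay, 4-isopropylphenyl in place of 3-methoxyphenyl gives a 1.5-fold higher number from compound 2 to compound 3 (0.17 log units; within the scatter), so this exchange, which alters both the group and its place on the ring, cannot be told apart from scatter. With the 4-methoxyphenyl group as the starting point, isopropyl in place of methoxy gives a 3.1-fold higher number from compound 1 to compound 3 (0.49 log units; beyond the scatter), which shows that changing the group alone can shift the number. No supporting measurement accounts for this shift. Still open, as far as these compounds go, is how an unsubstituted phenyl, or a 4-chlorophenyl or 4-fluorophenyl group, would behave on this chain carbon.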